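The source may hold more compounds than are shown below. What is called first, only, known or untested is meant among the compounds shown, and "the series" means these compounds.

Measured compounds:
compound 1 `Cc1ccc2c(Cc3nn4cc(-c5ccc(Cl)cc5)nc4s3)coc2c1` — 42.1%
compound 2 `Cc1ccc2c(Cc3nn4cc(-c5ccc(Br)cc5)nc4s3)coc2c1` — 12%

In a functional assay on the whole organism (strain Wistar albino) for inhibition, with Rattus norvegicus as the target, read by paw edema, with a stated time of 2 h, at a dose of 100 mg/kg by the oral route (a higher number here means more inhibition at the dose given (going by the name of the read-out), a lower number less inhibition), compound 1 gives 42.1% and compound 2 gives 12%. Compound 2 stands lowest of the two numbers, and its nearest neighbour is compound 1, which lies a number 30.1 percentage points lower from compound 1 to compound 2 (beyond the scatter); that single step rests on a bromo in place of chloro on an aromatic carbon.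

Compound 3 `Cc1ccc2c(Cc3nn4c(CO)c(-c5ccc(Br)cc5)nc4s3)coc2c1` has not yet been tested. It differs from compound 2 by hydroxymethyl in place of hydrogen on an aromatic carbon. Among the measured compounds shown here, no measured step involves a hydroxymethyl or any other change at that place, so the one known step, a number 30.1 percentage points lower from compound 1 to compound 2 (beyond the scatter), does not bear on it directly and offers no guide to direction. The expectation is therefore a change no larger than the usual scatter, in either direction, from compound 2 to compound 3, namely a number 8 percentage points higher from compound 2 to compound 3 (within the scatter). Compound 3 is estimated at 20%, within a range from 5% to 40%.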

Compound 3, a percentage reported as inhibition, in the whole organism at one dose (the size of the read-out at that dose, not a potency): 13.1%
Compound 3: middle estimate off by 6.9 percentage points, on the high side; low and high end bracket the measured number.
By their numbers in this assay, from the lowest: compounds 2 and 3 (each within the scatter of the next); then compound 1.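

In this assay, hydroxymethyl in place of hydrogen on this aromatic carbon, which lies next to the ring nitrogen and next to the ring atom that bears a 4-bromophenyl group, gives a number 1.1 percentage points higher from compound 2 to compound 3 (within the scatter). So with the 4-bromophenyl group in place, this position of the core can carry hydroxymethyl, with its hydrogen-bond donor and acceptor, without a shift beyond the scatter in paw edema inhibition. Nothing measured here offers a reason for this result.

The compounds shown pair hydroxymethyl only with the 4-bromophenyl group, so what it does alongside the 4-chlorophenyl group of compound 1 stays open. Also open, going by these compounds, is how an amine, a carboxylic acid or a longer chain at this same place would read out.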